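The source may report more compounds than this note shows. Statements on the series, on what has been measured and on what is new or still open speak of the compounds shown alone.

Measured so far in an ADME assay on Huh-5-2 cells (Homo sapiens) for cytotoxicity, read by WST assay, with a stated time of 3 days; on this read-out lower numbers stand for higher toxicity in this test and higher numbers for lower toxicity in this test:
compound 1 `N#Cc1cccc(COc2c(-c3ccccc3)oc3cc(O)cc(O)c3c2=O)c1`: 21000 nM
compound 2 `O=c1c(OCc2cccc([N+](=O)[O-])c2)c(-c2ccccc2)oc2cc(O)cc(O)c12`: 31000 nM
compound 3 `COc1cccc(COc2c(-c3ccccc3)oc3cc(O)cc(O)c3c2=O)c1`: 28000 nM

Compound 3 stands second highest of the three, nearest to compound 2 and furthest from compound 1, with both gaps inside the scatter. Compound 4 `COc1ccc(COc2c(-c3ccccc3)oc3cc(O)cc(O)c3c2=O)cc1` differs from compound 3 by 4-methoxyphenyl in place of 3-methoxyphenyl on a saturated chain carbon bound to an oxygen on an aromatic ring, which read one bond further out is 3-methoxybenzyl to 4-methoxybenzyl. The steps measured so far swap the group on that ring: a 1.5-fold higher number from compound 1 to compound 2 (0.17 log units; within the scatter), a 1.3-fold higher number from compound 1 to compound 3 (0.12 log units; within the scatter), a 1.1-fold lower number from compound 2 to compound 3 (0.04 log units; within the scatter). For the measured compounds named here, none moves the number beyond the scatter, and no step moves a group within the ring, so the bearing is indirect. The expected step is no change at the digits printed from compound 3 to compound 4 (within the scatter), none beyond the scatter. Compound 4 is estimated at 28000 nM, range 15000 nM to 50000 nM.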

Compound 4, half-maximal cytotoxic concentration: 57000 nM
Beside the measured number, compound 4's estimate is 2.0-fold (0.31 log units) below it; the whole stated range lies below it.
By their numbers in this assay, from the lowest: compounds 1, 3, 2 and 4 (each within the scatter of the next, the first and the last beyond it).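

In this assay, for the compounds shown here, a 2.0-fold higher number from compound 3 to compound 4 (0.31 log units; beyond the scatter) is the first step beyond the scatter: 4-methoxyphenyl in place of 3-methoxyphenyl keeps the group and changes only where it sits on the ring. a 2.7-fold higher number from compound 1 to compound 4 (0.43 log units; beyond the scatter) also lies beyond the scatter, while a 1.8-fold higher number from compound 2 to compound 4 (0.26 log units; within the scatter) stays within it, so compound 4 does not separate from all three earlier compounds. Nothing measured here accounts for the shift.

On these data alone, whether 4-cyanophenyl or 4-nitrophenyl would follow the methoxy pair remains open. So does the effect of an amine or a carboxylic acid on that ring, or of a longer chain in place of the benzyl link.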